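tert-Butoxycarbonyl on the aminophenyl nitrogen: working notes

The compounds below may be only part of what the source reports. "The series", "measured", "known", "first", "only" and "open" are said of these compounds alone.

Measured in an assay for inhibition of Fatty-acid amide hydrolase 1 (Rattus norvegicus); a higher number here means a weaker inhibitor, a lower number a stronger inhibitor:
compound 1, `Nc1cccc(CCCCCCC(=O)c2ncc(-c3ccccn3)o2)c1`, gives 30 nM
compound 2, `Nc1ccc(CCCCCCC(=O)c2ncc(-c3ccccn3)o2)cc1`, gives 3 nM
compound 3, `CC(C)(C)OC(=O)Nc1cccc(CCCCCCC(=O)c2ncc(-c3ccccn3)o2)c1`, gives 2.4 nM

The two cores differ by 4-aminophenyl in place of 3-aminophenyl on a saturated chain carbon, six bonds along the chain from a carbonyl carbon, and this step is a 10-fold lower number from compound 1 to compound 2 (1.00 log units; beyond the scatter). Capping the nitrogen of compound 1, the change (tert-butoxycarbonyl in place of hydrogen on a nitrogen on an aromatic ring), gives a 13-fold lower number from compound 1 to compound 3 (1.10 log units; beyond the scatter). Compound 2 and compound 3 sit within the scatter of each other, so nothing separates them.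

Compound 4, `CC(C)(C)OC(=O)Nc1ccc(CCCCCCC(=O)c2ncc(-c3ccccn3)o2)cc1`, is not yet measured. It carries tert-butoxycarbonyl in place of hydrogen on a nitrogen on an aromatic ring, the same change as from compound 1 to compound 3, at the same place on the ring. On the core of compound 1 that change was large, a 13-fold lower number from compound 1 to compound 3 (1.10 log units; beyond the scatter), and the same direction is expected here. Because compound 2 already gives 3 nM, the expected step to compound 4 is put smaller than the earlier one, at a 5.0-fold lower number from compound 2 to compound 4 (0.70 log units; beyond the scatter) in this assay. Compound 4 is therefore estimated at 0.6 nM, with a likely range from 0.15 nM to 3 nM.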

Compound 4, inhibition constant: 5.6 nM
For compound 4 the middle estimate is 9.3-fold (0.97 log units) below the measured one; the measured number lies above the stated range.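

In this assay, tert-butoxycarbonyl on the nitrogen of the 4-aminophenyl core gives a 1.9-fold higher number from compound 2 to compound 4 (0.27 log units; within the scatter) and so does not separate compound 4 from compound 2. The same change therefore cannot be carried from the 3-aminophenyl core to the 4-aminophenyl core as a fixed step in this assay, since the two steps differ: the same change on two cores in this assay, a 13-fold lower number (1.10 log units; beyond the scatter) from compound 1 to compound 3 and a 1.9-fold higher number (0.27 log units; within the scatter) from compound 2 to compound 4, 23-fold (1.37 log units) apart, beyond the scatter of two such steps. Among these compounds, this shows that the result of the change depends on the core in this pair, but with only two cores it gives no rule for a further core and does not show what produces the difference.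

As far as these compounds go, it remains open whether a smaller group on the nitrogen, such as acetyl, follows compound 3 or compound 4 on the two cores. Also open, from the compounds shown here alone, is whether the dependence on the core persists with a carboxylic acid in place of the amine or with a shorter chain.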